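This account rests on a few compounds, and the source may have more. Where it says the series, first, only, none or still open, it means among the compounds named here.

Measured so far in a functional assay on the whole organism for antagonist activity, with Mus musculus as the target; a lower number here means that less compound is needed, a higher number that more compound is needed for the effect:
- Compound 1 `Cn1c(-c2ccccc2)nnc1S(C)(=O)=O`: 55 mg/kg
- Compound 2 `CSc1nnc(-c2ccccc2Cl)n1C`: > 50 mg/kg, a limit
- Compound 3 `CSc1nnc(-c2ccccc2F)n1C`: 61.3 mg/kg

In this assay, compound 3 at 61.3 mg/kg and compound 1 at 55 mg/kg lie within the scatter of each other. Compound 2 gives only a limit, > 50 mg/kg, and not a number.

Compound 4 `CC[S+]([O-])c1nnc(-c2ccccc2F)n1C` differs from compound 3 in one group: a group of 4 heavy atoms (2 carbon, 1 oxygen, 1 sulfur; no ring) in place of a group of 2 heavy atoms (1 carbon, 1 sulfur; no ring), on an aromatic carbon. The methylsulfanyl leaves an aromatic carbon between two ring nitrogen atoms, and the larger group takes its place.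

Among the measured compounds shown here, the only measured step, a step that the limit leaves unreadable from compound 2 to compound 3, concerns a different change, and its size cannot be read. For the measured compounds named here, no measured step therefore gives a size for this replacement, so the expectation stays close to compound 3 at 61.3 mg/kg, with a wide margin on either side. The expected change is a 1.4-fold lower number from compound 3 to compound 4 (0.13 log units; within the scatter), which would be no shift beyond the scatter. The estimate for compound 4 is 45 mg/kg, with an expected range of 15 mg/kg to 110 mg/kg.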

Compound 4, dose for half-maximal effect: > 200 mg/kg
Compound 4: no number, only a limit (the forecaster's own chance of this, stated with the estimate: 25%); middle value at least 4.4-fold (0.64 log units) away from the limit.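

In this assay, the place on the aromatic carbon between two ring nitrogen atoms now has its first readable step: replacing the methylsulfanyl with the group of 4 heavy atoms gives an at least 3.2-fold higher number from compound 3 to compound 4 (0.51 log units; beyond the scatter). Among the compounds shown here, until now, no step showed that a change at this place could move the dose beyond the scatter, and here more compound is needed for the effect. Compound 4 gives only a limit, so the step has a lower bound but no full size: the limit of > 200 mg/kg in this assay, at which 1 of the 4 values shown sits.

The replacement adds carbon and oxygen together, so the compounds shown leave open which of the two goes with the higher number. An ethylsulfanyl group at this place would bear on that question, while an amine there would show whether a group without sulfur is read differently.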